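From methyl to chloro on compound 3

The compounds below may be only part of what the source reports. "The series", "measured", "known", "first", "only" and "open" are said of these compounds alone.

In a functional assay on NCI-H661 cells (Homo sapiens) for antiproliferative activity, read by MTT assay, with a stated time of 72 h (a higher number here means a weaker inhibitor, a lower number a stronger inhibitor), compound 1 `Cc1ccc(-c2noc(CCCCCCC(=O)NO)n2)cc1` gives 15800 nM and compound 2 `O=C(CCCCCCc1nc(-c2ccc(C(F)(F)F)cc2)no1)NO` gives 15300 nM. Compound 3 `Cc1ccc(-c2noc(CCCCCCC(=O)Nc3ccccc3N)n2)cc1` gives 410 nM, the lowest of the three numbers and beyond the scatter from both others. Placing 2-aminophenyl in place of hydroxy on an amide-type nitrogen produced the large step of a 39-fold lower number from compound 1 to compound 3 (1.59 log units; beyond the scatter), but that change lies elsewhere in the molecule and says little about what comes next.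

Compound 4 `Nc1ccccc1NC(=O)CCCCCCc1nc(-c2ccc(Cl)cc2)no1` has chloro in place of methyl on an aromatic carbon, para to a large group: chloro in place of methyl on an aromatic carbon. The closest evidence is trifluoromethyl in place of methyl at that carbon, the step of a 1.0-fold lower number from compound 1 to compound 2 (0.01 log units; within the scatter), which lies within the scatter. As far as these compounds go, that step was seen with hydroxy rather than 2-aminophenyl on the nitrogen, and chloro itself is untested, so some uncertainty remains. No step beyond the scatter is expected. The estimated step is a 1.0-fold lower number from compound 3 to compound 4 (0.01 log units; within the scatter). For compound 4 the expected value is 400 nM, with an estimated range from 170 nM to 950 nM.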

Compound 4, half-maximal inhibitory concentration: 11200 nM
For compound 4 the middle estimate is 28-fold (1.45 log units) below the measured one; measured number above the stated range.
By their numbers in this assay, from the lowest: compound 3; then compounds 4, 2 and 1 (each within the scatter of the next).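

In this assay, the step of a 27-fold higher number from compound 3 to compound 4 (1.44 log units; beyond the scatter) shows that this carbon, para to a large group, is far from indifferent when 2-aminophenyl sits on the amide nitrogen. The earlier change at the same carbon, a 1.0-fold lower number from compound 1 to compound 2 (0.01 log units; within the scatter), showed almost nothing, but it differed in two ways: it carried hydroxy on the nitrogen, and trifluoromethyl rather than chloro entered. The data shown offer no measurement that accounts for the large step.

As far as these compounds go, it remains open whether this large step is specific to chloro or would follow from replacing methyl with other groups, such as fluoro or methoxy, on the 2-aminophenyl series. A chloro compound with hydroxy on the nitrogen is also absent from the compounds shown, so the role of that nitrogen group in the step stays unsettled.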